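A few compounds are considered here, and "the series" means these few. Any claim that something is new, unique, unknown or untested is made for them only; others in the source may bear on it.

Compound 1 `Nc1ncnc2c1ncn2[C@@H]1CO[C@H](COS(=O)(=O)NC(=O)[C@@H]2CCCN2)[C@@H](O)C1` gives 2800 nM in a functional assay on PBMC cells (Homo sapiens) for inhibition (on this read-out lower numbers stand for stronger inhibition and higher numbers for weaker inhibition), the second highest of the three numbers measured. Compound 2 `Nc1ncnc2c1ncn2[C@@H]1CO[C@H](COS(=O)(=O)NC(=O)[C@@H]2CCCN2)[C@@H](O)[C@H]1O` differs from it only by a hydroxy in place of hydrogen on a saturated ring carbon, and in this assay compound 2 gives 750 nM, so that a 3.7-fold lower number from compound 1 to compound 2 (0.57 log units; beyond the scatter). Compound 3 `CCC[C@H](N)C(=O)NS(=O)(=O)OC[C@H]1O[C@@H](n2cnc3c(N)ncnc32)[C@H](O)[C@@H]1O` is built on the same core as compound 2 but without the pyrrolidin-2-yl ring on the carbonyl carbon; in this assay compound 3 gives 4700 nM, a higher number than compound 2 and close to that of compound 1, within the scatter.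

Compound 4 `C[C@H](N)C(=O)NS(=O)(=O)OC[C@H]1OC[C@@H](n2cnc3c(N)ncnc32)C[C@@H]1O` keeps the core of compound 1 and changes the acyl group: 1-aminoethyl in place of pyrrolidin-2-yl on a carbonyl carbon. Among the compounds with values here, no measured step covers this change on the core of compound 1 itself. Within the data shown here, the only indication comes from compounds 2 and 3, where the compound that lacks the pyrrolidin-2-yl ring gives the higher number. Compound 4 is therefore expected to give a higher number than compound 1, with a 2.9-fold higher number from compound 1 to compound 4 (0.46 log units; beyond the scatter) as the estimated step in this assay, though with wide uncertainty because the open-chain group in compound 3 is not the 1-aminoethyl group of compound 4. Compound 4 is estimated at 8000 nM, with a range from 2500 nM to 25000 nM.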

Compound 4, half-maximal inhibitory concentration: 5500 nM
Compound 4: middle estimate off by 1.5-fold (0.16 log units), on the high side; the range from low to high includes it.
By their numbers in this assay, from the lowest: compound 2; then compounds 1, 3 and 4 (each within the scatter of the next).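

On the core of compound 1 itself, the exchange of pyrrolidin-2-yl for 1-aminoethyl on a carbonyl carbon gives in this assay a 2.0-fold higher number from compound 1 to compound 4 (0.29 log units; within the scatter), so the two groups cannot be told apart on this read-out. The ring and its two extra heavy atoms are therefore not needed on this core to keep the number in this range, although both compounds stay within the scatter of each other and neither can be placed ahead of the other. No measured finding offers a reason for this result, and the step itself is silent on the matter.

The compounds shown leave open whether 1-aminoethyl would also match pyrrolidin-2-yl on the core of compound 2, which carries the extra hydroxy and gives the lowest number of the set. They also leave open how this position would respond to a six-membered piperidin-2-yl ring, a longer chain carrying the amine, or an acyl group with no amine at all, such as plain ethyl, and whether the defined stereocentre in the acyl group matters.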